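The source may hold more compounds than are shown below. What is called first, only, known or untested is meant among the compounds shown, and "the series" means these compounds.

In a functional assay on MCF7 cells (Homo sapiens) for cytotoxicity (a lower number here means a stronger inhibitor, a higher number a weaker inhibitor), compound 1 (`Nc1ccc(-c2nc3ccc(O)cc3s2)cc1Cl`) gives 54500 nM, a weak result. Compound 2 (`Nc1ccc(-c2nc3ccccc3s2)cc1I`) reads < 1 nM in this assay. As far as these compounds go, that reading is a limit of the assay and not a number, so the true value of compound 2 remains unknown.

Compound 3 (`Nc1ccc(-c2nc3ccccc3s2)cc1Cl`) is built from compound 2 by a single exchange: chloro in place of iodo on an aromatic carbon. In plain terms, this puts chloro in place of iodo on an aromatic carbon, ortho to an amino group and meta to a group of 9 heavy atoms. The rest of the structure stays the same.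

Among the measured compounds shown here, no measured pair of compounds here shows what an exchange of this kind does, so its size has to be judged with caution. For the measured compounds named here, since only one atom changes, the expected outcome is a modest step toward weaker inhibition, or none beyond the scatter, with compound 3 staying far from the weak end set by compound 1. The expected step is a number no lower from compound 2 to compound 3 (the limit leaves the size open). For compound 3, the estimated value is 1 nM, with an expected range of 0.3 nM to 30 nM.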

Compound 3, half-maximal inhibitory concentration: < 1 nM
Compound 3: a limit, no number; the forecaster's own chance of this, stated with the estimate: 55%; the middle value lies on the limit itself.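

Compound 3 reads as a limit in this assay, just as compound 2 does, so with either chloro or iodo at this place, ortho to an amino group, the reading stays at the strong end of what this assay can report, and the step between the two cannot be read: the limit of < 1 nM in this assay, at which 2 of the 3 values shown sit.

Among the compounds shown here, compound 3 also supplies the first comparison here that can be read, as it differs from compound 1 in one place only: hydrogen in place of hydroxy on an aromatic carbon gives an at least 54000-fold lower number from compound 1 to compound 3 (4.73 log units; beyond the scatter). For the compounds shown here, the one large change visible in these compounds therefore goes with the loss of the hydroxy group, while any effect of the chloro and iodo exchange stays hidden.

The compounds shown leave open how chloro and iodo truly rank, which would take readings that are numbers rather than limits. They also leave open what a different group at this same place, such as methyl or a carboxylic acid, would do to the reading, and whether adding hydroxy to compound 2 would weaken it as much.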